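The source may hold more compounds than are shown below. What is called first, only, known or untested is meant among the compounds shown, and "the series" means these compounds.

Compound 1 `O=C(/C=C/c1ccc(OCc2cn(Cc3ccc(F)cc3)nn2)cc1)c1ccc(Br)cc1` and compound 2 `O=C(/C=C/c1ccc(OCc2cn(Cc3ccccc3F)nn2)cc1)c1ccc([N+](=O)[O-])cc1` share a core and differ in two places at once, so the gap between them cannot be read as a single step. In a functional assay on A549 cells (Homo sapiens) for inhibition, read by MTT assay, with a stated time of 48 h, tested at 10 uM (on this read-out lower numbers stand for less inhibition of growth and higher numbers for more inhibition of growth at the one concentration tested), compound 1 gives 43%. In this assay compound 2 gives 43%, level with compound 1 at the digits shown and within the scatter of it. Compound 3 `O=C(/C=C/c1ccc(OCc2cn(Cc3ccc(F)cc3)nn2)cc1)c1ccc([N+](=O)[O-])cc1` has the same atoms as compound 2, joined differently: 4-fluorophenyl in place of 2-fluorophenyl on a saturated chain carbon bound to an aromatic nitrogen, or, cut one bond further out, 2-fluorobenzyl to 4-fluorobenzyl. Among the measured compounds shown here, no measured pair shows this move on its own. Compound 3 carries the 4-fluorophenyl of compound 1 and the nitro-bearing ring of compound 2, and both of those gave the same reading, so no step beyond the scatter is expected from compound 2 to compound 3 in this assay, the expected step being no change at the digits printed from compound 2 to compound 3 (within the scatter). Compound 3 is therefore estimated at 43%, with a range from 30% to 56%.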

Compound 3, percent growth inhibition at one concentration: 34%
For compound 3 the middle estimate is 9 percentage points above the measured one, and the stated range covers the measured number.
By their numbers in this assay, from the lowest: compounds 3, 1 and 2 (each within the scatter of the next).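

Among the compounds shown here, with the nitro-bearing ring held fixed, 4-fluorophenyl in place of 2-fluorophenyl on a saturated chain carbon bound to an aromatic nitrogen gives a number 9 percentage points lower from compound 2 to compound 3 (within the scatter) in this assay and is the first reading of this position on its own. For the compounds shown here, with the 4-fluorobenzyl held fixed, nitro in place of bromo on an aromatic carbon gives a number 9 percentage points lower from compound 1 to compound 3 (within the scatter) and is likewise the first single-place reading of that change, so neither swap separates these compounds at the one concentration tested. Nothing available bears on why these readings fall as they do.

As far as these compounds go, whether the benzyl position tolerates more than a fluorine shift remains open, for example with 3-fluorobenzyl, an unsubstituted benzyl or a longer chain. From the compounds shown here alone, it is also open whether an amine or a carboxylic acid in place of nitro would give a step beyond the scatter.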